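Flipping one ring stereocentre: what compound 4 may do

The compounds below may be only part of what the source reports. "The series", "measured", "known", "first", "only" and "open" are said of these compounds alone.

Values measured in a functional assay on Lu1 cells (Homo sapiens) for cytotoxicity, read by colorimetric assay and neutral red uptake, with a stated time of 72 h (on this read-out higher numbers stand for weaker inhibition and lower numbers for stronger inhibition), are these
compound 1 `CO[C@@H](C(=O)N[C@H]1CCCCNC1=O)[C@H](O)[C@@H](O)[C@H](O)/C=C/C(C)(C)C` gives 4300 nM
compound 2 `CO[C@@H](C(=O)N[C@H]1CC[C@@H](O)CNC1=O)[C@H](O)[C@@H](O)[C@H](O)/C=C/C(C)(C)C` gives 23400 nM
compound 3 `CO[C@@H](C(=O)N[C@H]1CC[C@H](O)CNC1=O)[C@H](O)[C@@H](O)[C@H](O)/C=C/C(C)(C)C` gives 10000 nM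

Compound 3 sits in the middle of these three numbers, as shown by a 2.3-fold higher number from compound 1 to compound 3 (0.37 log units; beyond the scatter) and by a 2.3-fold lower number from compound 2 to compound 3 (0.37 log units; beyond the scatter) on its other side. The next structure is compound 4 `CO[C@@H](C(=O)N[C@@H]1CC[C@H](O)CNC1=O)[C@H](O)[C@@H](O)[C@H](O)/C=C/C(C)(C)C` and it differs from compound 3 in one way: the two compounds have the same atoms and bonds and differ only in configuration as drawn: 1 of 7 stereo elements differ; a stereocentre at a saturated ring carbon is drawn S in compound 3 and R in compound 4 and no atom enters or leaves.

The closest guide is the fact that compounds 2 and 3 differ only in the configuration as drawn and that flip gave a 2.3-fold lower number from compound 2 to compound 3 (0.37 log units; beyond the scatter) which is modest though beyond the scatter. Among the measured compounds shown here, the largest step so far, a 5.4-fold higher number from compound 1 to compound 2 (0.74 log units; beyond the scatter) is also modest. However, compound 4 flips a different stereocentre, one drawn alike in all three measured compounds, so its effect has not been measured directly. A step somewhat larger than those seen is therefore expected, leaning towards weaker inhibition, although this direction is only a tentative judgement. The expected change is a 3.0-fold higher number from compound 3 to compound 4 (0.48 log units; beyond the scatter) in this assay for now. For compound 4 the estimate is 30000 nM with an expected range from 8000 nM to 100000 nM in the same test.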

Compound 4, half-maximal inhibitory concentration: 36300 nM
The estimate for compound 4 lay 1.2-fold (0.08 log units) below the measured number, and the stated range covers the measured number.
By their numbers in this assay, from the lowest: compound 1; then compound 3; then compounds 2 and 4 (each within the scatter of the next).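

A second ring stereocentre also matters in this assay: flipping it alone gives a 3.6-fold higher number from compound 3 to compound 4 (0.56 log units; beyond the scatter), and with no atom entering or leaving, this change can only come from the spatial arrangement: the fact that compounds 3 and 4 differ only in the configuration as drawn. Among the compounds shown here, with both ring stereocentres drawn the other way there is a 1.6-fold higher number from compound 2 to compound 4 (0.19 log units; within the scatter), so compound 3 is the only hydroxy compound here whose number stands clear of the other two. The 6-hydroxy-2-oxoazepan-3-yl group of compound 4 also gives an 8.4-fold higher number from compound 1 to compound 4 (0.93 log units; beyond the scatter), and compound 1, which lacks the hydroxy group, keeps the lowest number of the four.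

From the compounds shown here alone, it remains open whether flipping this same stereocentre in compound 1 would shift the number in the same direction without the hydroxy group. Going by these compounds, it is also open whether an amine or a methoxy group on that ring carbon would behave like the hydroxy group.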